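The source may report more compounds than this note shows. Statements on the series, on what has been measured and on what is new or still open speak of the compounds shown alone.

In a functional assay on HL-60 cells (Homo sapiens) for cytotoxicity (on this read-out lower numbers stand for stronger inhibition and higher numbers for weaker inhibition), compound 1 `C/C(=C/c1cccc(C(=O)O)c1)c1ccc2c(c1)C(C)(C)CCC2(C)C` gives 50000 nM. Compound 2 `CC1(C)CCC(C)(C)c2cc(/C=C/c3ccc(N)cc3)ccc21` gives 18000 nM, and compound 3 `CC1(C)CCC(C)(C)c2cc(/C=C\c3ccc(N)cc3)ccc21` gives 18000 nM. These two are the same molecule apart from how the double bond is drawn (the fact that compounds 2 and 3 differ only in the configuration as drawn), and the step of no change at the digits printed from compound 2 to compound 3 (within the scatter) shows that this drawn configuration made no difference. Compound 3 thus stands level with compound 2, the two sharing the lowest number of the three, while compound 1 sits at a higher number. Compound 4 `CC1(C)CCC(C)(C)c2cc(/C=C\c3cccc(N)c3)ccc21` differs from compound 3 in a single place: 3-aminophenyl in place of 4-aminophenyl on a double-bonded chain carbon bound to a double-bonded chain carbon. For the measured compounds named here, no measured step moves the amino group around its ring, and the only measured step concerned drawn configuration alone, leaving no direction to lean on. Compound 4 is therefore expected to stay about level, the step being no change at the digits printed from compound 3 to compound 4 (within the scatter), with an estimated 18000 nM between 6000 nM and 50000 nM.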

Compound 4, half-maximal inhibitory concentration: 10000 nM
The estimate for compound 4 lay 1.8-fold (0.26 log units) above the measured number; the range from low to high includes it.
By their numbers in this assay, from the lowest: compounds 4, 2 and 3 (each within the scatter of the next); then compound 1.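

In this assay, the first measured move of the amino group around its ring, 3-aminophenyl in place of 4-aminophenyl, gives a 1.8-fold lower number from compound 3 to compound 4 (0.26 log units; within the scatter) and so stays inside the usual spread of repeat measurements. At this place on the chain, the two amino positions therefore cannot be told apart in this read-out. Nothing available bears on why they read alike.

Still open, going by these compounds, is whether a different group on this ring, such as a hydroxyl or a methoxy, would shift the number beyond that spread.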